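The source may hold more compounds than are shown below. What is called first, only, known or untested is meant among the compounds shown, and "the series" means these compounds.

Working notes on the series, continued. Compound 1 `CCCN(CCC(F)(F)F)Cc1c(C(F)(F)F)nc2n(-c3c(C)cc(C)cc3C)c(Cl)cn12` gives 12 nM in an assay on cells for displacement of a labelled ligand from corticotropin-releasing factor receptor 1 (Homo sapiens), with a stated time of 100 min; on this read-out higher numbers stand for weaker inhibition and lower numbers for stronger inhibition; compound 2 `Cc1cc(C)c(-n2c(Cl)cn3c(CN(CCC(F)(F)F)Cc4ccc(F)cc4)c(C(F)(F)F)nc23)c(C)c1` gives 34 nM, and compound 3 `CCCN(Cc1ccccc1)Cc1c(C(F)(F)F)nc2n(-c3c(C)cc(C)cc3C)c(Cl)cn12` gives 170 nM, the highest number of the three, beyond the scatter from both others. The next step leads to compound 4 `CCCN(Cc1ccc(F)cc1)Cc1c(C(F)(F)F)nc2n(-c3c(C)cc(C)cc3C)c(Cl)cn12`, with fluoro in place of hydrogen on an aromatic carbon, para to a large group. Within the data shown here, no measured step makes this exact change. The nearest comparisons are a 2.8-fold higher number from compound 1 to compound 2 (0.45 log units; beyond the scatter) and a 14-fold higher number from compound 1 to compound 3 (1.15 log units; beyond the scatter), but each swaps a whole chain and so reads on the change from compound 3 to compound 4 only loosely; compound 2, which carries the 4-fluorobenzyl group, sits well below compound 3 yet differs from it elsewhere too. For compound 4 in this assay the expected step is a 1.4-fold lower number from compound 3 to compound 4 (0.15 log units; within the scatter), small and uncertain in direction. Compound 4 is therefore estimated at 120 nM, within 50 nM to 300 nM.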

Compound 4, inhibition constant: 350 nM
Estimate against measurement, compound 4: 2.9-fold (0.46 log units) below; measured number above the stated range.
By their numbers in this assay, from the lowest: compound 1; then compound 2; then compound 3; then compound 4.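

Fluoro in place of hydrogen on the aromatic carbon para to a large group does not help here: the number rises by a modest step (a 2.1-fold higher number from compound 3 to compound 4 (0.31 log units; beyond the scatter)). With the 4-fluorobenzyl group held, methyl in place of trifluoromethyl on the chain costs far more (a 10-fold higher number from compound 2 to compound 4 (1.01 log units; beyond the scatter)), and the widest gap in the set separates the two ends of the order (a 29-fold higher number from compound 1 to compound 4 (1.46 log units; beyond the scatter)).

Open, on these data alone, is whether chloro or methoxy on that aromatic carbon would follow fluoro, and what a longer chain on the amine nitrogen would do. No evidence on the cause of these steps is at hand.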